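The source may hold more compounds than are shown below. What is called first, only, known or untested is meant among the compounds shown, and "the series" means these compounds.

Working notes on the series. Within the data shown here, compound 1 `Cc1ccccc1Nc1nc(Nc2cccnc2)ncc1Cl` is the one member with an actual number in a functional assay on MCF7 cells (Homo sapiens) for inhibition, read by CCK-8 assay, with a stated time of 48 h; a lower number here means a stronger inhibitor of growth, a higher number a weaker inhibitor of growth: in this assay compound 1 gives 56500 nM. Compound 2 `Cc1ccccc1Nc1nc(NC2CCCCC2)ncc1Cl` returns only a limit of the assay in this assay, > 100000 nM. Compound 3 `Cc1ccccc1Nc1nc(NCc2ccco2)ncc1Cl` likewise returns a limit, > 100000 nM. Two of the three values thus sit at the limit of > 100000 nM in this assay, at which 2 of the 3 values shown sit, which leaves the measured steps poorly defined. Replacing pyridin-3-yl with cyclohexyl gives an at least 1.7-fold higher number from compound 1 to compound 2 (0.24 log units; that floor lies within the scatter); replacing it with (furan-2-yl)methyl gives an at least 1.7-fold higher number from compound 1 to compound 3 (0.24 log units; that floor lies within the scatter); the comparison between the cyclohexyl and (furan-2-yl)methyl members is a step that the two limits leave unreadable from compound 2 to compound 3. All that can be read is that leaving the pyridin-3-yl group costs at least a small amount and possibly much more.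

Compound 4 `Cc1ccccc1Nc1nc(Nc2cc(Cl)ccn2)ncc1Cl` keeps an aromatic ring with one nitrogen at the same position on the core, differing from compound 1 by 4-chloropyridin-2-yl in place of pyridin-3-yl on a nitrogen on an aromatic ring. Among the measured compounds shown here, no measured step covers this kind of exchange; the two limits only show that departing from a pyridine ring altogether did not help. Compound 4 is therefore expected to stay near compound 1, with a step of a 1.3-fold lower number from compound 1 to compound 4 (0.10 log units; within the scatter) that is not expected to exceed the scatter, and an estimated value of 45000 nM (range 12000 nM to 150000 nM).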

Compound 4, concentration for 50% growth inhibition: > 100000 nM
Compound 4: a limit, no number (the forecaster's own chance of this, stated with the estimate: 30%); middle value at least 2.2-fold (0.34 log units) away from the limit.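

In this assay, a pyridine-type ring on the same nitrogen of the shared core is not enough to keep a measurable number: 4-chloropyridin-2-yl in place of pyridin-3-yl gives an at least 1.7-fold higher number from compound 1 to compound 4 (0.24 log units; that floor lies within the scatter). Compound 4 returns only a limit, > 100000 nM, so the earlier finding that the cyclohexyl and (furan-2-yl)methyl members give limits now extends to a member that keeps an aromatic ring with one nitrogen, although the size of this step stays undefined. Among these compounds, the steps from compound 2 and from compound 3 to compound 4 cannot be read, and compound 1 remains the only member with an actual number: the limit of > 100000 nM in this assay, at which 3 of the 4 values shown sit.

Going by these compounds, compound 4 differs from compound 1 both in the chlorine and in the ring attachment, so the contribution of each stays open, and plain pyridin-2-yl or 4-chloropyridin-3-yl on the same nitrogen would separate the two. Also open, on these data alone, is whether any group at this place gives a lower number than compound 1, for instance phenyl, pyridin-4-yl or a phenyl ring carrying a morpholine.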